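From methoxy to hydroxy in compound 3

This account rests on a few compounds, and the source may have more. Where it says the series, first, only, none or still open, it means among the compounds named here.

compound 1 `COc1ccc(C(=O)c2cc(OC)c(OC)c(OC)c2)c(NC(=O)CO)c1` gives 70 nM
compound 2 `CCNCC(=O)Nc1cc(OC)ccc1C(=O)c1cc(OC)c(OC)c(OC)c1` gives 2100 nM
compound 3 `C=C(c1cc(OC)c(OC)c(OC)c1)c1ccc(OC)c(O)c1NC(=O)COC` gives 330 nM

All three were tested in a functional assay on HeLa cells (Homo sapiens) for antiproliferative activity, read by MTT assay, with a stated time of 48 h (on this read-out higher numbers stand for weaker inhibition and lower numbers for stronger inhibition), and compound 3 holds the middle place, with a higher number than compound 1 and a lower one than compound 2. Compound 4 `C=C(c1cc(OC)c(OC)c(OC)c1)c1ccc(OC)c(O)c1NC(=O)CO` differs from it by one small change: hydrogen in place of methyl on an oxygen on a saturated carbon, turning methoxymethyl into hydroxymethyl.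

Among the measured compounds shown here, no measured pair isolates this swap. The nearest evidence is a 30-fold higher number from compound 1 to compound 2 (1.48 log units; beyond the scatter), a large step for ethylamino in place of hydroxy on a saturated chain carbon bound to a carbonyl carbon. It is a different swap, but it shows that a change there can move the number strongly. The (hydroxymethyl)carbonyl group of compound 4 also occurs in compound 1 at 70 nM, although the core of compound 1 differs, so it is only a loose guide.

A moderate step towards a lower number is therefore expected in this assay, and a step within the scatter remains possible. The expected change is a 2.4-fold lower number from compound 3 to compound 4 (0.37 log units; beyond the scatter) as estimated here. For compound 4 the estimated value is 140 nM, with an expected range from 50 nM to 400 nM.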

Compound 4, half-maximal inhibitory concentration: 20 nM
For compound 4 the middle estimate is 7.0-fold (0.85 log units) above the measured one; measured number below the stated range.
By their numbers in this assay, from the lowest: compound 4; then compound 1; then compound 3; then compound 2.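

In this assay, among the compounds shown here, the swap of methoxymethyl to hydroxymethyl gives a 17-fold lower number from compound 3 to compound 4 (1.22 log units; beyond the scatter), the first step here in which this change stands alone on an otherwise unchanged molecule. For the compounds shown here, the earlier compounds showed only that a different swap on this chain could move the number strongly, and towards weaker inhibition. This pair shows that the loss of a single methyl, one carbon as the only heavy atom, can also move it strongly, and towards stronger inhibition, although no measurement here accounts for the size of the step.

The compounds shown leave open how other groups in this place, such as aminomethyl or a carboxylic acid, would compare with hydroxymethyl. They also leave open whether methoxy to hydroxy would give a step of similar size on the core of compound 1.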